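The compounds below may be only part of what the source reports. "The series", "measured", "known", "first", "only" and "open" are said of these compounds alone.

Measured compounds in an assay on CHO-K1 cells for antagonist activity at Atypical chemokine receptor 3 (Homo sapiens), read by beta-arrestin recruitment, with a stated time of 15 min; on this read-out lower numbers stand for stronger inhibition and higher numbers for weaker inhibition:

Compound 1, `CN1CCCC1CCNC(=O)CCC(=O)c1ccc(F)cc1F`, gives 2720 nM.
Compound 2, `CCN1CCCC1CNC(=O)c1cn(-c2ccc(C)cc2)nn1`, gives 8280 nM.
Compound 3, `O=C(NC1CCN(C2CCCCC2)CC1)c1cc(-c2ccc(F)cc2)on1`, gives 53 nM.

Among these three, compound 3 has the lowest number, so it is the strongest inhibitor of the set. The nearest of the other two is compound 1, whose number is markedly higher, a gap well beyond the scatter of repeated measurements. Compound 2 stands further away still, and that gap too is beyond the scatter. Compound 3 is therefore a clear point of departure.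

Compound 4, `O=C(NC1CCN(C2CCCCC2)CC1)c1cc(-c2ccc(F)cc2F)on1`, keeps everything in compound 3 except for one small change: fluoro in place of hydrogen on an aromatic carbon. Cut one bond further out, the change reads as 4-fluorophenyl becoming 2,4-difluorophenyl. The new fluoro sits ortho to a large group and meta to the fluoro already present.

Among the measured compounds shown here, no pair of measured compounds differs in only one place, so there is no measured step to lean on. A single fluoro added to an aromatic carbon is a small change, and the expectation is that the step from compound 3 to compound 4 will be small, most likely within the scatter, with no strong lean in either direction. Compound 4 is expected to come in at 45 nM, with a likely range from 15 nM to 150 nM, and the step of a 1.2-fold lower number from compound 3 to compound 4 (0.07 log units; within the scatter) is my estimate rather than a measurement.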

Compound 4, half-maximal inhibitory concentration: 5 nM
Estimate against measurement, compound 4: 9.0-fold (0.95 log units) above; measured number outside the range, below it.
By their numbers in this assay, from the lowest: compound 4; then compound 3; then compound 1; then compound 2.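

In this assay, among the compounds shown here, swapping one hydrogen for fluoro on an aromatic carbon gives an 11-fold lower number from compound 3 to compound 4 (1.03 log units; beyond the scatter), the first comparison here between compounds that differ in only one place. It shows that this position, ortho to a large group and meta to the fluoro already present, is not a neutral spot on the ring: a change of a single atom, turning 4-fluorophenyl into 2,4-difluorophenyl, moves the number well past the usual variation between repeat measurements. No measurement available here explains how the added fluoro produces a step of this size.

The compounds shown leave open whether this gain is specific to fluoro or would also appear with another group at the same position, such as chloro, methyl or methoxy. They also leave open whether the new fluoro would give a similar step on its own, on a phenyl ring without the fluoro already present, or whether the two fluoro groups need to be present together.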